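This account rests on a few compounds, and the source may have more. Where it says the series, first, only, none or still open, it means among the compounds named here.

Measured so far:
Compound 1, `COc1ccccc1C(=O)c1oc2cc(-c3ccccc3)cc(O)c2c1C`, 0.09 ug/mL.
Compound 2, `COc1ccc(OC)c(C(=O)c2oc3cc(-c4ccccc4)cc(O)c3c2C)c1`, 0.09 ug/mL.
Compound 3, `Cc1c(C(=O)c2ccccc2-c2ccccc2)oc2cc(-c3ccccc3)cc(O)c12`, 0.1 ug/mL.

Three compounds share a core and were tested in a functional assay on WI-38 VA13 cells (Homo sapiens) for cytotoxicity; a higher number here means that more compound is needed for the effect, a lower number that less compound is needed. Compound 1 gives 0.09 ug/mL. Compound 2 gives 0.09 ug/mL, and compound 3 gives 0.1 ug/mL. Compound 1 stands level with compound 2 and, together with it, at the lowest of the three numbers; the move no change at the digits printed from compound 1 to compound 2 (within the scatter) shows no change, and a 1.1-fold higher number from compound 1 to compound 3 (0.05 log units; within the scatter) is also within the scatter. All three numbers sit close together.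

Compound 4, `Cc1c(C(=O)Cc2ccccc2)oc2cc(-c3ccccc3)cc(O)c12`, is not yet measured. It differs from compound 1 in one place: benzyl in place of 2-methoxyphenyl on a carbonyl carbon.

Neither measured step touches this change. The steps of no change at the digits printed from compound 1 to compound 2 (within the scatter) and a 1.1-fold higher number from compound 1 to compound 3 (0.05 log units; within the scatter) vary what sits on the aromatic ring attached to the carbonyl carbon and show that this part tolerates alteration without movement in this assay. Compound 4, however, exchanges that ring for a benzyl group, a change of a different kind, so the measured steps give only a loose anchor. The expectation is therefore a step of a 1.7-fold higher number from compound 1 to compound 4 (0.22 log units; within the scatter), with a wide range around it. For compound 4 the estimate in this assay is 0.15 ug/mL, expected to fall between 0.05 ug/mL and 0.6 ug/mL.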

Compound 4, half-maximal effective concentration: > 4 ug/mL
Compound 4: only a limit was reported; the forecaster's own chance of this, stated with the estimate: 5%; at least 26-fold (1.42 log units) between middle value and limit.
By their numbers in this assay, from the lowest: compounds 1, 2 and 3 (each within the scatter of the next). At a limit, above all of these: compound 4.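

The carbonyl carbon looked tolerant while only the aromatic ring on it was varied, with no change at the digits printed from compound 1 to compound 2 (within the scatter) and a 1.1-fold higher number from compound 1 to compound 3 (0.05 log units; within the scatter), but in this assay the group on this carbon proves far from indifferent: benzyl in place of 2-methoxyphenyl gives an at least 44-fold higher number from compound 1 to compound 4 (1.64 log units; beyond the scatter). Both groups carry one six-membered aromatic ring of carbon only, so the presence of such a ring does not by itself keep the number low, and the loss of the methoxy oxygen does not account for the jump on its own, as compound 3 also has none in that place and stays within the scatter of compound 1. The value of compound 4 is a limit and not a number: the limit of > 4 ug/mL in this assay, at which 1 of the 4 values shown sits.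

The compounds shown leave open whether this large step belongs to benzyl alone or extends to other groups on the carbonyl carbon, such as a longer chain ending in phenyl, a plain alkyl chain or an amine. On these data alone, how far compound 4 lies past its limit also stays open, so the step has a lower bound only.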